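The compounds below may be only part of what the source reports. "The series", "measured", "known", "first", "only" and "open" are said of these compounds alone.

Measured compounds and values in a physicochemical assay for solubility, read by HPLC, in phosphate buffer, with a stated time of 24 h, at pH 6.5; a lower number here means a less soluble compound, a higher number a more soluble compound:
- compound 1 `CCCS(=O)(=O)Nc1ccc(F)c(C(=O)Nc2cnc3[nH]ncc3c2)c1F` gives 80 ug/mL
- compound 2 `CCCS(=O)(=O)Nc1ccc(F)c(C(=O)Nc2cnc3[nH]nc(N(C)C)c3c2)c1F` gives 290 ug/mL
- compound 3 `CCCS(=O)(=O)Nc1ccc(F)c(C(=O)Nc2cnc3[nH]nc(OC)c3c2)c1F` gives 4 ug/mL

Compound 3 stands lowest of the three numbers in this assay. The nearest is compound 1, reached by a 20-fold lower number from compound 1 to compound 3 (1.30 log units; beyond the scatter); the furthest is compound 2, reached by a 73-fold lower number from compound 2 to compound 3 (1.86 log units; beyond the scatter). Both steps are beyond the scatter, so compound 3 is clearly the least soluble of the measured set.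

Compound 4 `CCCS(=O)(=O)Nc1ccc(F)c(C(=O)Nc2cnc3[nH]nc(Br)c3c2)c1F` differs from compound 3 by bromo in place of methoxy on an aromatic carbon. Among the compounds with values here, no measured step introduces a bromo, so the expectation rests only indirectly on the steps to hand: the methoxy cost a large amount in a 20-fold lower number from compound 1 to compound 3 (1.30 log units; beyond the scatter), and the dimethylamino gained a modest amount in a 3.6-fold higher number from compound 1 to compound 2 (0.56 log units; beyond the scatter). Bromo brings no acceptor, so the step is expected to be small, with perhaps a modest recovery toward compound 1, stated as a 1.8-fold higher number from compound 3 to compound 4 (0.24 log units; within the scatter). Compound 4 is therefore estimated at 7 ug/mL, within 1.5 ug/mL to 30 ug/mL.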

Compound 4, solubility: 1 ug/mL
The estimate for compound 4 lay 7.0-fold (0.85 log units) above the measured number; measured number below the stated range.
By their numbers in this assay, from the lowest: compound 4; then compound 3; then compound 1; then compound 2.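

In this assay, bromo on this aromatic carbon goes lower than methoxy, with a 4.0-fold lower number from compound 3 to compound 4 (0.60 log units; beyond the scatter) in this swap, so methoxy does not mark the low end at this position. The wider comparisons, an 80-fold lower number from compound 1 to compound 4 (1.90 log units; beyond the scatter) against hydrogen and a 290-fold lower number from compound 2 to compound 4 (2.46 log units; beyond the scatter) against dimethylamino, place compound 4 at the bottom of the set; bromo and methoxy both stand below hydrogen, and only dimethylamino stands above it. Removing the hydrogen-bond acceptor of methoxy therefore brings no recovery here, and nothing available gives a reason for these differences.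

Still open, on these data alone, is whether chloro or fluoro on this carbon would follow bromo. Also open, as far as these compounds go, is whether a cyclic amine such as morpholine, or a carboxylic acid, would sit above hydrogen as dimethylamino does.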